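The compounds below may be only part of what the source reports. "The series", "measured", "known", "first", "only" and "open" are said of these compounds alone.

Compound 1 `c1ccc2c(c1)CCC2NC1CCN(CCCc2c[nH]c3ccc(-n4cnnc4)cc23)CC1`: 8.9 nM
Compound 2 `C[C@H](NCC1CCN(CCCc2c[nH]c3ccc(-n4cnnc4)cc23)CC1)c1ccccc1`: 4.4 nM

In an assay on CHO cells for displacement of a labelled ligand from 5-hydroxytryptamine receptor 1D (Homo sapiens) (a higher number here means a weaker inhibitor, a lower number a stronger inhibitor), compound 2 holds the lowest of the two numbers; its nearest neighbour is compound 1, and the step between them is a 2.0-fold lower number from compound 1 to compound 2 (0.31 log units; beyond the scatter). Compound 3 `c1ccc(NCC2CCN(CCCc3c[nH]c4ccc(-n5cnnc5)cc34)CC2)nc1` is not yet measured. It differs from compound 2 by pyridin-2-yl in place of 1-phenylethyl on an amine nitrogen. Going by the values given here, the only measured step that bears on this position is a 2.0-fold lower number from compound 1 to compound 2 (0.31 log units; beyond the scatter), a modest change in which a different saturated-carbon group was exchanged on the same amine nitrogen. Among the compounds with values here, no measured pair shows an aromatic ring placed directly on that nitrogen, so the size of the coming step is uncertain. A modest loss in this assay is expected, estimated as a 2.7-fold higher number from compound 2 to compound 3 (0.44 log units; beyond the scatter), because a 2.0-fold lower number from compound 1 to compound 2 (0.31 log units; beyond the scatter) was itself modest and gives no ground for a large shift. Compound 3 is therefore expected near 12 nM, with a range of 3 nM to 50 nM.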

Compound 3, half-maximal inhibitory concentration: 1.7 nM
The estimate for compound 3 lay 7.1-fold (0.85 log units) above the measured number, and the stated range ends above it.
By their numbers in this assay, from the lowest: compound 3; then compound 2; then compound 1.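

In this assay, an aromatic ring placed directly on the amine nitrogen is tolerated: pyridin-2-yl in place of 1-phenylethyl gives a 2.6-fold lower number from compound 2 to compound 3 (0.41 log units; beyond the scatter) and shows that, in this pair, neither the saturated-carbon attachment nor the defined stereocentre of 1-phenylethyl is needed for a low number. Exchanging (2,3-dihydro-1H-inden-1-yl)amino for ((pyridin-2-yl)amino)methyl on the saturated ring carbon gives a 5.2-fold lower number from compound 1 to compound 3 (0.72 log units; beyond the scatter) and places the new group ahead of both earlier amine substituents. Nothing available accounts for the direction of either step.

The pyridin-2-yl change swaps the ring and its attachment together, so the contribution of the ring nitrogen remains unresolved. A plain phenyl on the same amine nitrogen would separate these two changes, and pyridin-3-yl or pyridin-4-yl would test whether the ring nitrogen's placement matters.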